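From compound 2 to compound 3: one aromatic ring exchanged

A few compounds are considered here, and "the series" means these few. Any claim that something is new, unique, unknown or untested is made for them only; others in the source may bear on it.

- Compound 1 (`CC1C(=O)NN=C1c1ccc(-n2ccnc2)cc1`) gives (> 1 mg/kg) as a limit
- Compound 2 (`CC1(C)C(=O)NN=C1c1ccc(-n2ccnc2)cc1`) gives (0.18 mg/kg) as a number

Among the measured compounds shown here, in a functional assay on the whole organism (Myocardium) with Canis familiaris (Canis lupus familiaris) as the target (on this read-out lower numbers stand for an effect already at smaller amounts and higher numbers for an effect only at larger amounts of compound), compound 2 gives (0.18 mg/kg) as the only true number so far. Compound 1 gives (> 1 mg/kg) and this is a limit. For the measured compounds named here, the one measured step (an at least 5.5-fold lower number from compound 1 to compound 2 (0.74 log units; beyond the scatter)) is beyond the scatter, but it belongs to a different change, methyl in place of hydrogen on a saturated ring carbon. Compound 3 (`CC1(C)C(=O)NN=C1c1ccc(-c2ccncc2)cc1`) keeps the core of compound 2 with one difference (pyridin-4-yl in place of 1H-imidazol-1-yl on an aromatic carbon). Going by the values given here, no measured step covers this exchange, so no size carries over. In this assay the expected step (a 1.1-fold higher number from compound 2 to compound 3 (0.05 log units; within the scatter)) is small, with no firm direction. Compound 3 is estimated at (0.2 mg/kg) with an expected range from (0.05 mg/kg) to (0.8 mg/kg) for now.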

Compound 3, dose for half-maximal effect: 0.3 mg/kg
Compound 3: middle estimate off by 1.5-fold (0.18 log units), on the low side; measured number inside the range.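

In this assay, pyridin-4-yl in place of 1H-imidazol-1-yl gives a 1.7-fold higher number from compound 2 to compound 3 (0.22 log units; within the scatter). This position on the aromatic ring therefore accepts a six-membered ring with one nitrogen as well as a five-membered ring with two, and this read-out cannot tell the two compounds apart. Nothing measured here bears on this exchange. On these data alone, what stays open is whether a ring nitrogen matters at this place at all: a plain phenyl ring or a dimethylamino group there would test that.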